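Methyl to Nitro: Expecting Compound 4

The compounds below may be only part of what the source reports. "The series", "measured", "known", "first", "only" and "open" are said of these compounds alone.

Measured in a toxicity assay on the whole organism with Rattus norvegicus as the target, at a dose of 400 mg/kg by the oral route; a higher number here means a stronger effect of the compound at the dose given, a lower number a weaker effect:
- compound 1, `Clc1ccc(OCC2=NCCO2)cc1`: 90%
- compound 2, `Cc1ccccc1OCC1=NCCO1`: 100%
- compound 3, `Brc1ccc(OCC2=NCCO2)cc1`: 100%

Compound 2 matches compound 3 at the digits shown, and compound 1 differs from both only within the scatter, so the three numbers cannot be told apart. Among the compounds with values here, the only step measured between single-change neighbours is a number 10 percentage points higher from compound 1 to compound 3 (within the scatter), a swap of one halogen for another on the aromatic ring, and it stays within the scatter. Compound 4, `O=[N+]([O-])c1ccccc1OCC1=NCCO1`, differs from compound 2 as follows: nitro in place of methyl on an aromatic carbon. Within the data shown here, no measured step exchanges methyl for nitro, so the halogen step bears on it only as a sign that small changes on this ring left this assay flat. The step of a number 5 percentage points lower from compound 2 to compound 4 (within the scatter) is therefore expected to stay within the scatter. Compound 4 is estimated at 95%, between 75% and 100%.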

Compound 4, a percentage reported as activity, at one dose (the size of the read-out at that dose, not a potency): 90%
The estimate for compound 4 lay 5 percentage points above the measured number; measured number inside the range.
By their numbers in this assay, from the lowest: compounds 1, 4, 2 and 3 (each within the scatter of the next).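

Nitro in place of methyl on this aromatic carbon, ortho to a group of 7 heavy atoms, gives a number 10 percentage points lower from compound 2 to compound 4 (within the scatter) in this assay. The flat picture therefore now extends beyond a swap of one halogen for another: here 3 heavy atoms and 2 hydrogen-bond acceptors enter where 1 heavy atom left, and the step still stays within the scatter. No measurement here explains this result.

From the compounds shown here alone, whether an amine, a carboxylic acid or a longer chain on this carbon would also stay within the scatter remains open.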